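A few compounds are considered here, and "the series" means these few. Any claim that something is new, unique, unknown or untested is made for them only; others in the source may bear on it.

Of the compounds shown here, three built on one shared core have been tested in a functional assay on NCI-H1299 cells (Homo sapiens) for antiproliferative activity, read by XTT assay, with a stated time of 72 h; on this read-out higher numbers stand for weaker inhibition and lower numbers for stronger inhibition. Compound 1 `COc1ccc(-c2cc3ccccc3nc2/C=C/C(=O)c2ccc(F)cc2)cc1` gives 820 nM in this assay. Compound 2 `COc1ccc(-c2cc3ccccc3nc2/C=C/C(=O)c2ccc(OC)cc2OC)cc1` gives 3770 nM. Compound 3 `COc1ccc(-c2cc3ccccc3nc2/C=C/C(=O)c2c(OC)cccc2OC)cc1` gives 4710 nM, the highest of the three numbers; its nearest neighbour is compound 2 and its furthest is compound 1. The move from compound 3 to the unmeasured compound 4 `COc1ccc(-c2cc3ccccc3nc2/C=C/C(=O)c2ccc(OC)c(OC)c2)cc1` is 3,4-dimethoxyphenyl in place of 2,6-dimethoxyphenyl on a carbonyl carbon. Two kinds of measured step bear on this change. Swapping the 4-fluorophenyl group for a dimethoxyphenyl group gave a 4.6-fold higher number from compound 1 to compound 2 (0.66 log units; beyond the scatter) and a 5.7-fold higher number from compound 1 to compound 3 (0.76 log units; beyond the scatter). Exchanging one dimethoxyphenyl arrangement for another gave a 1.2-fold higher number from compound 2 to compound 3 (0.10 log units; within the scatter), a step that stays within the scatter. Compound 4 carries a dimethoxyphenyl group of a third arrangement, so the expected step in this assay is a 1.2-fold lower number from compound 3 to compound 4 (0.07 log units; within the scatter), not beyond the scatter. Compound 4 is therefore estimated at 4000 nM, with a range from 1500 nM to 10000 nM.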

Compound 4, half-maximal inhibitory concentration: 1050 nM
Compound 4: middle estimate off by 3.8-fold (0.58 log units), on the high side, and the stated range ends above it.
By their numbers in this assay, from the lowest: compounds 1 and 4 (each within the scatter of the next); then compounds 2 and 3 (each within the scatter of the next).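

In this assay, the arrangement of the two methoxy groups on the phenyl ring attached to the carbonyl carbon clearly matters: moving to the 3,4-dimethoxyphenyl group brings a 4.5-fold lower number from compound 3 to compound 4 (0.65 log units; beyond the scatter) and a 3.6-fold lower number from compound 2 to compound 4 (0.56 log units; beyond the scatter), even though the atoms stay the same and are only joined differently. The earlier compounds shown here suggested that dimethoxyphenyl groups as a class gave higher numbers than 4-fluorophenyl, but the step here is a 1.3-fold higher number from compound 1 to compound 4 (0.11 log units; within the scatter), so this arrangement stays within the scatter of the 4-fluorophenyl compound. Nothing available here explains why the arrangement has this effect.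

Among these compounds, it remains open how a phenyl ring carrying only one methoxy group would behave at this position. The outcome with an amine or a carboxylic acid on this ring is also unknown.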